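A Longer Alkenyl Amide on a Weakly Active Series

This account rests on a few compounds, and the source may have more. Where it says the series, first, only, none or still open, it means among the compounds named here.

Compound 1 `COc1ccc(Nc2nc(Oc3cccc(NC(=O)/C=C/C(C)C)c3)c3sccc3n2)cc1` gives 45100 nM in a functional assay on HeLa cells (Homo sapiens) for inhibition, read by MTT assay, with a stated time of 72 h; on this read-out higher numbers stand for weaker inhibition and lower numbers for stronger inhibition.
Compound 2 `COc1cccc(Nc2nc(Oc3cccc(NC(=O)C=C(C)C)c3)c3sccc3n2)c1` gives 26100 nM in this assay.

Compound 2 holds the lowest of these two numbers, but compound 1 sits only slightly higher and the gap lies within the usual scatter, so the two cannot be told apart. Compound 3 `COc1cccc(Nc2nc(Oc3cccc(NC(=O)/C=C/C(C)C)c3)c3sccc3n2)c1` arises from compound 2 by 3-methylbut-1-en-1-yl in place of 2-methylprop-1-en-1-yl on a carbonyl carbon. Among the compounds with values here, since the two measured compounds differ in more than one place, no single step for this change is known. In this assay the change is expected to bring no step beyond the scatter, in either direction. Compound 3 is estimated at 33000 nM, within 11000 nM to 100000 nM. This means an expected step of a 1.3-fold higher number from compound 2 to compound 3 (0.10 log units; within the scatter).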

Compound 3, half-maximal inhibitory concentration: 27000 nM
Beside the measured number, compound 3's estimate is 1.2-fold (0.09 log units) above it; the measured number falls inside the stated range.
By their numbers in this assay, from the lowest: compounds 2, 3 and 1 (each within the scatter of the next).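

In this assay, 3-methylbut-1-en-1-yl in place of 2-methylprop-1-en-1-yl on a carbonyl carbon gives a 1.0-fold higher number from compound 2 to compound 3 (0.01 log units; within the scatter) and so leaves the two compounds indistinguishable. On a nitrogen on an aromatic ring, 3-methoxyphenyl in place of 4-methoxyphenyl gives a 1.7-fold lower number from compound 1 to compound 3 (0.22 log units; within the scatter) and so also stays unresolved, now as a true one-place comparison. No measurement available here offers an explanation for either result.

From the compounds shown here alone, whether a longer chain, an amine or a carboxylic acid on this carbonyl carbon would move the number beyond the scatter remains open.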